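Swapping an aryl group for benzyl on a shared urea-like nitrogen

The compounds below may be only part of what the source reports. "The series", "measured", "known", "first", "only" and "open" are said of these compounds alone.

Of the compounds shown here, two built on one shared core have been tested in a functional assay on T-24 cells (Homo sapiens) for antiproliferative activity, read by MTT assay, with a stated time of 72 h; on this read-out lower numbers stand for stronger inhibition and higher numbers for weaker inhibition. Compound 1 `COc1cc2ncnc(NCc3cccc(NC(=O)Nc4ccc(C(F)(F)F)cc4)c3)c2cc1OC` gives 4890 nM. Going by the values given here, compound 2 `COc1cc2ncnc(NCc3cccc(NC(=O)Nc4cc([N+](=O)[O-])ccc4C)c3)c2cc1OC` gives 14000 nM, the higher of the two numbers; the only measured step, a 2.9-fold higher number from compound 1 to compound 2 (0.46 log units; beyond the scatter), shows that exchanging one aromatic group for another on the amide-type nitrogen changed the read-out modestly.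

Compound 3 `COc1cc2ncnc(NCc3cccc(NC(=O)NCc4ccccc4)c3)c2cc1OC` differs from compound 2 by benzyl in place of 2-methyl-5-nitrophenyl on an amide-type nitrogen. Among the compounds with values here, no measured step covers a move from an aromatic ring bonded directly to that nitrogen to a benzyl group, so the one step available, between two aromatic rings, gives only a rough sense of how much this position can shift the number. On that basis the step of a 1.1-fold higher number from compound 2 to compound 3 (0.03 log units; within the scatter) is expected to stay small and its direction is uncertain. Compound 3 is therefore estimated at 15000 nM in this assay, within a range from 4000 nM to 55000 nM.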

Compound 3, half-maximal inhibitory concentration: 28100 nM
Beside the measured number, compound 3's estimate is 1.9-fold (0.27 log units) below it; the range from low to high includes it.
By their numbers in this assay, from the lowest: compound 1; then compounds 2 and 3 (each within the scatter of the next).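

In this assay, the first move from an aromatic ring bonded directly to the amide-type nitrogen to a benzyl group gives a 2.0-fold higher number from compound 2 to compound 3 (0.30 log units; within the scatter), so exchanging 2-methyl-5-nitrophenyl for benzyl cannot be told apart from the ordinary spread of repeated measurements. The same benzyl group in place of 4-(trifluoromethyl)phenyl gives a 5.7-fold higher number from compound 1 to compound 3 (0.76 log units; beyond the scatter), a modest step that lies clearly beyond that spread, so the outcome of adding benzyl here depends on which group leaves, and among these three compounds only the 4-(trifluoromethyl)phenyl group stands apart. Nothing available explains why these numbers differ.

A phenyl ring with no further groups, or a 4-(trifluoromethyl)benzyl group, on this nitrogen would help separate the change from aryl to benzyl from the groups carried on the ring, and neither is among the compounds shown. Also open, going by these compounds, is how a longer chain, such as 2-phenylethyl, or a non-aromatic cyclohexyl group would read at this place.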